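A few compounds are considered here, and "the series" means these few. Any claim that something is new, unique, unknown or untested is made for them only; others in the source may bear on it.

Measured compounds:
- compound 1 `Cc1cc2c(c(N)nn2C)c(N2CCCCC2)n1` gives 17%
- compound 2 `COCCNc1nc(C)cc2c1c(N)nn2C` gives 5%

Both were tested in an assay on isolated protein for inhibition of MAP kinase-activated protein kinase 5 (Homo sapiens), read by mobility shift assay, tested at 30 uM; on this read-out lower numbers stand for less inhibition and higher numbers for more inhibition at the one concentration tested (going by the name of the read-out). Compound 2 stands at the lower of the two numbers shown, and the nearest is compound 1, which lies higher by a step described as beyond the scatter. Going by the values given here, that one measured step, a number 12 percentage points lower from compound 1 to compound 2 (beyond the scatter), is the only comparison available: exchanging one substituent for another on the shared core lowered the read-out modestly, from a number that was itself small.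

Compound 3 `Cc1cc2c(cn1)c(N)nn2C` is not yet measured. It differs from compound 2 in one place: hydrogen in place of (2-methoxyethyl)amino on an aromatic carbon. Among the compounds with values here, no measured pair shows what happens when a substituent at this position is taken away entirely, so the one step at hand bears on it only loosely. With compound 2 already near the bottom of the scale, there is little room for a further drop, and a rise beyond the scatter has no support in the two numbers shown.

The expected change from compound 2 to compound 3 is therefore a number 1 percentage points higher from compound 2 to compound 3 (within the scatter), within the scatter. Compound 3 is estimated at 6%, with a range from -4% to 16%.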

Compound 3, a percentage reported as inhibition, at one concentration (the size of the read-out at that concentration, not a potency): 9%
Compound 3: middle estimate off by 3 percentage points, on the low side; low and high end bracket the measured number.
By their numbers in this assay, from the lowest: compounds 2, 3 and 1 (each within the scatter of the next, the first and the last beyond it).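

Compound 3 carries only hydrogen on the aromatic carbon next to the ring nitrogen, so it shows what this position gives with no substituent there at all. In this assay, going by these compounds alone, the removal of the chain gives a number 4 percentage points higher from compound 2 to compound 3 (within the scatter) and the removal of the ring gives a number 8 percentage points lower from compound 1 to compound 3 (within the scatter) and thus neither (2-methoxyethyl)amino nor piperidin-1-yl can be told apart from bare hydrogen on this read-out, although the two groups stand apart from each other, with a number 12 percentage points lower from compound 1 to compound 2 (beyond the scatter) as the only step beyond the scatter. Nothing in hand explains why these numbers fall as they do.

All three compounds are read at a single concentration and give small numbers, so what they show is a narrow band of weak inhibition, not a potency for any of them. Open, on these data alone, is whether a different group on this carbon, such as a plain amine, a carboxylic acid or a phenyl ring, would lift the read-out clear of the scatter around compound 3 and give this position a measurable effect.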